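Swapping the Carbonyl-Bound Ring in a Chalcone-Like Series

A few compounds are considered here, and "the series" means these few. Any claim that something is new, unique, unknown or untested is made for them only; others in the source may bear on it.

Measured compounds:
- compound 1, `COc1cc(-c2cc(/C=C/C(=O)c3ccc(N)cc3)[nH]n2)cc(OC)c1OC`: -98%
- compound 2, `COc1ccc(-c2cc(/C=C/C(=O)c3ccc(OC)c(OC)c3)[nH]n2)cc1`: -71%

Both compounds were tested in a functional assay on HOP-62 cells (Homo sapiens) for cytotoxicity, read by sulforhodamine B assay, with a stated time of 48 h, tested at 100 uM; on this read-out lower numbers stand for a stronger effect and higher numbers for a weaker effect at the one concentration tested. Compound 1 gives -98%, the lowest of the two numbers, which here means the stronger effect. Compound 2 gives -71%, a number that lies beyond the usual scatter above that of compound 1.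

Compound 3, `COc1ccc(C(=O)/C=C/c2cc(-c3cc(OC)c(OC)c(OC)c3)n[nH]2)cc1OC`, has not been measured. It differs from compound 1 in one place: 3,4-dimethoxyphenyl in place of 4-aminophenyl on a carbonyl carbon.

Among the compounds with values here, no measured pair differs in exactly this one place, so no step can be read off directly. Compound 2 does carry the same 3,4-dimethoxyphenyl on its carbonyl carbon, and its number is higher than that of compound 1. On that basis, a modest step towards a higher number is expected, a number 13 percentage points higher from compound 1 to compound 3 (beyond the scatter), though the ring on the other side of the shared core also differs between compound 2 and compound 3. Compound 3 is therefore estimated at -85%, with a range from -100% to -60%.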

Compound 3, a percentage reported as activity, at one concentration (the size of the read-out at that concentration, not a potency): -98%
For compound 3 the middle estimate is 13 percentage points above the measured one, and the stated range covers the measured number.
By their numbers in this assay, from the lowest: compounds 1 and 3 (each within the scatter of the next); then compound 2.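

In this assay, putting 3,4-dimethoxyphenyl in place of 4-aminophenyl on a carbonyl carbon gives no change at the digits printed from compound 1 to compound 3 (within the scatter) on this core. This position therefore accepts a group with more heavy atoms and no hydrogen-bond donor, without the numbers of the two compounds separating. The 3,4-dimethoxyphenyl that compound 2 also carries on its carbonyl carbon therefore cannot, on this evidence, be taken alone as a sign of a weaker effect.

Nothing available explains why these two groups read alike.

As far as these compounds go, whether a carboxylic acid or a hydroxyl group on this phenyl ring would read the same remains open. From the compounds shown here alone, it is also open whether a plain unsubstituted phenyl would do so, and whether this swap would behave alike on the core of compound 2.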